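From a pyridine to a phenyl on the unsaturated chain

The source may report more compounds than this note shows. Statements on the series, on what has been measured and on what is new or still open speak of the compounds shown alone.

Compound 1 `O=C(/C=C/c1ccccc1)C[C@@H]1O[C@H](CO)[C@@H](O[C@@H]2O[C@H](CO)[C@@H](O)[C@H](O)[C@H]2O)[C@H](O)[C@H]1O` and compound 2 `O=C(/C=C/c1cccnc1)C[C@@H]1O[C@H](CO)[C@@H](O)[C@H](O)[C@H]1O` carry the same unsaturated chain on a sugar core. In an assay on isolated protein for inhibition of lysosomal alpha-glucosidase (Rattus norvegicus), tested at 100 uM (a higher number here means more inhibition at the concentration tested (going by the name of the read-out), a lower number less inhibition), compound 1 gives -24.6%, and compound 2 gives -35.4%, the lowest of the two numbers, with compound 1 standing higher by a gap beyond the usual scatter. Compound 3 `O=C(/C=C/c1ccccc1)C[C@@H]1O[C@H](CO)[C@@H](O)[C@H](O)[C@H]1O` differs from compound 2 by phenyl in place of pyridin-3-yl on a double-bonded chain carbon bound to a double-bonded chain carbon. For the measured compounds named here, no measured pair isolates this change, so the step expected in this assay, a number 7.4 percentage points higher from compound 2 to compound 3 (within the scatter), is estimated to be small, upward, and within the scatter. Compound 3 is expected to give -28%, within a range from -48% to -8%.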

Compound 3, a percentage reported as inhibition, at one concentration (the size of the read-out at that concentration, not a potency): -10.4%
Beside the measured number, compound 3's estimate is 17.6 percentage points below it; low and high end bracket the measured number.
By their numbers in this assay, from the lowest: compound 2; then compound 1; then compound 3.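

this assay shows a number 25 percentage points higher from compound 2 to compound 3 (beyond the scatter) when phenyl replaces pyridin-3-yl, so the read-out responds to this single change on the double-bonded chain carbon. It also shows a number 14.2 percentage points higher from compound 1 to compound 3 (beyond the scatter) when hydrogen replaces 3,4,5-trihydroxy-6-(hydroxymethyl)oxan-2-yl on an oxygen on a saturated carbon, so that place responds as well. Nothing at hand accounts for either step. Going by these compounds, whether an amine or a carboxylic acid on the phenyl, or a longer chain, would move the number further remains open.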